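What Losing One Methoxy Might Do to Compound 3

The compounds below may be only part of what the source reports. "The series", "measured", "known", "first", "only" and "open" are said of these compounds alone.

Three related compounds have been tested so far in a functional assay on PC-3 cells (Homo sapiens) for cytotoxicity, read by WST assay, with a stated time of 48 h (on this read-out higher numbers stand for weaker inhibition and lower numbers for stronger inhibition), and all give high numbers. Here compound 3 `COc1ccc2c(C(=O)/C(C#N)=C/c3c[nH]c4ccc(OC)cc34)c[nH]c2c1` gives 37100 nM as its result, and compound 1 `COc1ccc2c(/C=C(\C#N)C(=O)c3c[nH]c4cc(OC)ccc34)c[nH]c2c1` gives 27000 nM as its result. These two values lie within the usual scatter of each other, so they cannot be ranked. Compound 2 `COc1ccc2c(C(=O)/C(C#N)=C/c3cn(Cc4ccc(Cl)cc4)c4ccccc34)c[nH]c2c1` gives > 50000 nM as its result, which is a limit of the assay and not a number.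

The next compound to be measured is compound 4 `COc1ccc2c(C(=O)/C(C#N)=C/c3c[nH]c4ccccc34)c[nH]c2c1` and it differs from compound 3 in one place only. The change is hydrogen in place of methoxy on an aromatic carbon in which hydrogen stands in place of methoxy on an aromatic carbon of a six-membered aromatic ring of carbon only, part of a fused or bridged system of two rings.

For the measured compounds named here, no two measured compounds differ in just one place, so nothing here shows directly what this swap does in this assay as a step. Without such evidence, no shift beyond the scatter is expected. The estimated change is a 1.1-fold lower number from compound 3 to compound 4 (0.05 log units; within the scatter) in size, and a reported limit would be no surprise. Compound 4 is expected at about 33000 nM with an estimated range from 14000 nM to 50000 nM on this read-out.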

Compound 4, half-maximal inhibitory concentration: 12000 nM
Beside the measured number, compound 4's estimate is 2.8-fold (0.44 log units) above it, and the stated range ends above it.
By their numbers in this assay, from the lowest: compound 4; then compounds 1 and 3 (each within the scatter of the next). At a limit, above all of these: compound 2.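

In this assay, hydrogen in place of methoxy on this aromatic carbon gives a 3.1-fold lower number from compound 3 to compound 4 (0.49 log units; beyond the scatter), which shows that this position matters for the read-out, something compounds 1 and 3 could not show when their values lay within the scatter of each other. Compound 1 carries its methoxy at another place on the same kind of ring, and hydrogen in place of that methoxy gives a 2.3-fold lower number from compound 1 to compound 4 (0.35 log units; beyond the scatter), so both methoxy compounds give higher numbers than the compound with neither group. Hydrogen in place of 4-chlorobenzyl on an aromatic nitrogen gives an at least 4.1-fold lower number from compound 2 to compound 4 (0.61 log units; beyond the scatter), but compound 2 stands at a limit and not at a number, so the full size of this step cannot be read: the limit of > 50000 nM in this assay, at which 1 of the 4 values shown sits.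

These compounds do not tell whether hydrogen itself is what counts on this carbon, and a fluorine atom, a methyl group or an amine there would help to settle that. They also leave open why the number falls, since nothing shown here measures what the methoxy group does in the cells.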